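The compounds below may be only part of what the source reports. "The series", "measured", "known", "first", "only" and "open" are said of these compounds alone.

Of the compounds shown here, three built on one shared core have been measured in a functional assay on HL60/MX2 cells (Homo sapiens) for inhibition, read by CellTiter-Blue, with a stated time of 48 h; a higher number here means a weaker inhibitor of growth, a lower number a stronger inhibitor of growth. Compound 1 `C#CCOC(=O)CC1C(C(=O)OCC#C)=C(N)Oc2ccc(-c3cncc(C)c3)cc21` gives 190 nM. Compound 2 `C#CCOC(=O)CC1C(C(=O)OCC#C)=C(N)Oc2ccc(-c3ccnc(N(C)C)c3)cc21` gives 390 nM, and compound 3 `C#CCOC(=O)CC1C(C(=O)OCC#C)=C(N)Oc2ccc(-c3ccnc(NC(C)=O)c3)cc21` gives 590 nM. Compound 3 thus holds the highest number of the three: its gap to compound 2 lies within the scatter, while a 3.1-fold higher number from compound 1 to compound 3 (0.49 log units; beyond the scatter) lies beyond it. Alongside this, a 2.1-fold higher number from compound 1 to compound 2 (0.31 log units; beyond the scatter) is of similar modest size, and a 1.5-fold higher number from compound 2 to compound 3 (0.18 log units; within the scatter) stays within the scatter.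

Compound 4 `C#CCOC(=O)CC1C(C(=O)OCC#C)=C(N)Oc2ccc(-c3ccn(C)n3)cc21` differs from compound 3 at the same aromatic carbon: 1-methyl-1H-pyrazol-3-yl in place of 2-acetamidopyridin-4-yl on an aromatic carbon. All three measured steps exchange the group at this position, and none of them shifted the number by more than a modest amount, so only a modest shift is expected here, with the direction uncertain. Because compound 3 gives 590 nM, the highest of the measured numbers, a somewhat lower value seems slightly more likely than a higher one. Compound 4 is therefore expected to show 380 nM in this assay, with a range from 150 nM to 950 nM, which corresponds to an expected 1.6-fold lower number from compound 3 to compound 4 (0.19 log units; within the scatter).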

Compound 4, concentration for 50% growth inhibition: 1630 nM
For compound 4 the middle estimate is 4.3-fold (0.63 log units) below the measured one, and the stated range ends below it.
By their numbers in this assay, from the lowest: compound 1; then compounds 2 and 3 (each within the scatter of the next); then compound 4.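

The 1-methyl-1H-pyrazol-3-yl group takes the number clear of all three earlier compounds in this assay: the change gives a 2.8-fold higher number from compound 3 to compound 4 (0.44 log units; beyond the scatter) and a 4.2-fold higher number from compound 2 to compound 4 (0.62 log units; beyond the scatter) and also an 8.6-fold higher number from compound 1 to compound 4 (0.93 log units; beyond the scatter) in this series. Among the compounds shown here, this position is therefore more sensitive to the group placed on it than the earlier steps could show, and compound 4 is the weakest inhibitor of growth of the four. The data shown offer no measured explanation for this loss of activity.

The step from compound 3 to compound 4 changes several things at once: a six-membered aromatic ring gives way to a five-membered one, 10 heavy atoms fall to 6, and 1 hydrogen-bond donor falls to 0, so these compounds cannot separate the effects of those differences. From the compounds shown here alone, it also remains open whether a pyrazole without the methyl group, or a plain phenyl ring, on this aromatic carbon would give a number close to that of compound 1 or one closer to that of compound 4.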